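Swapping one chloropyridinyl amide for another on a shared core

A few compounds are considered here, and "the series" means these few. Any claim that something is new, unique, unknown or untested is made for them only; others in the source may bear on it.

Measured so far in an ADME assay for permeability, using PAMPA; on this read-out lower numbers stand for lower permeability and higher numbers for higher permeability:
compound 1 `C=C(C)C(=O)Nc1cccc(-c2nc3ccccc3s2)c1` gives 987 10^-6 cm/s
compound 2 `CN(C)CCC(=O)Nc1cccc(-c2nc3ccccc3s2)c1` gives 2080 10^-6 cm/s
compound 3 `O=C(Nc1cccc(-c2nc3ccccc3s2)c1)c1ccc(Cl)nc1Cl` gives 104 10^-6 cm/s

Compound 3 stands lowest of the three, with a 9.5-fold lower number from compound 1 to compound 3 (0.98 log units; beyond the scatter) and a 20-fold lower number from compound 2 to compound 3 (1.30 log units; beyond the scatter), both beyond the scatter. Compound 4 `O=C(Nc1cccc(-c2nc3ccccc3s2)c1)c1ccncc1Cl` differs from compound 3 by 3-chloropyridin-4-yl in place of 2,6-dichloropyridin-3-yl on a carbonyl carbon. For the measured compounds named here, no measured step exchanges one chloropyridinyl for another; the steps from compound 1 and compound 2 to compound 3 only show how much the shared core's number fell when a small group on the carbonyl carbon gave way to the dichloropyridinyl. With one chlorine fewer and the ring nitrogen moved, the expected change in this assay is a 1.1-fold higher number from compound 3 to compound 4 (0.02 log units; within the scatter), nothing beyond the scatter. Compound 4 is therefore estimated at 110 10^-6 cm/s, between 40 10^-6 cm/s and 300 10^-6 cm/s.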

Compound 4, apparent permeability: 563 10^-6 cm/s
Compound 4: the middle estimate sits 5.1-fold (0.71 log units) below what was measured; the measured number lies above the stated range.
By their numbers in this assay, from the lowest: compound 3; then compounds 4 and 1 (each within the scatter of the next); then compound 2.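

In this assay, one chloropyridinyl cannot simply stand in for another on this carbonyl carbon: the exchange gives a 5.4-fold higher number from compound 3 to compound 4 (0.73 log units; beyond the scatter). The 3-chloropyridin-4-yl group cannot be told apart from the small 1-methylethenyl group, with a 1.8-fold lower number from compound 1 to compound 4 (0.24 log units; within the scatter), yet it stays short of the 2-(dimethylamino)ethyl group, with a 3.7-fold lower number from compound 2 to compound 4 (0.57 log units; beyond the scatter). No measurement shown here explains the exchange.

Going by these compounds, one chlorine left and the ring nitrogen moved in the same step, so their separate shares remain open. A 2-chloropyridin-3-yl group at this carbonyl carbon would help pull them apart.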